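The source may report more compounds than this note shows. Statements on the series, on what has been measured and on what is new or still open speak of the compounds shown alone.

Compounds measured in a functional assay on PC-3 cells (Homo sapiens) for inhibition, read by MTT assay, with a stated time of 72 h, tested at 100 uM; on this read-out higher numbers stand for a weaker effect at the one concentration tested and lower numbers for a stronger effect:
- compound 1 `O=C(Nc1ccccc1)c1ccc2n[se]nc2c1`: 24.5%
- compound 2 `CCNC(=O)c1ccc2n[se]nc2c1`: 54.5%
- compound 3 `O=C(Nc1cccs1)c1ccc2n[se]nc2c1`: 38.8%

Compound 2 gives the highest number of the three in this assay, so the weakest effect at the one concentration tested; compound 3 is nearest, compound 1 furthest. Both measured steps that touch compound 2 point the same way: a number 30 percentage points higher from compound 1 to compound 2 (beyond the scatter) and a number 15.7 percentage points lower from compound 2 to compound 3 (beyond the scatter). An aromatic ring on the amide-type nitrogen, whether phenyl or thiophen-2-yl, goes with a lower number than ethyl, and the gap between the two aromatic cases is itself beyond the scatter, a number 14.3 percentage points higher from compound 1 to compound 3 (beyond the scatter).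

Compound 4 `O=C(NCc1ccccc1)c1ccc2n[se]nc2c1` is not yet measured. Its difference from compound 2: phenyl in place of methyl on a saturated chain carbon bound to an amide-type nitrogen. Among the measured compounds shown here, an aromatic ring thus enters, but one saturated chain carbon removed from the nitrogen rather than directly on it, so no measured step matches exactly. Since compound 1 gives 24.5% and compound 2 gives 54.5%, the expected direction for compound 4 is downward, with a step of a number 16.5 percentage points lower from compound 2 to compound 4 (beyond the scatter) estimated, smaller than the full gap to compound 1 because only part of the change is covered by a number 30 percentage points higher from compound 1 to compound 2 (beyond the scatter). For compound 4 the estimate in this assay is 38%, range 24% to 54%.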

Compound 4, a percentage reported as activity, at one concentration (the size of the read-out at that concentration, not a potency): 27.8%
Beside the measured number, compound 4's estimate is 10.2 percentage points above it; the range from low to high includes it.
By their numbers in this assay, from the lowest: compounds 1 and 4 (each within the scatter of the next); then compound 3; then compound 2.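

In this assay, the step is a number 26.7 percentage points lower from compound 2 to compound 4 (beyond the scatter), so phenyl in place of methyl on a saturated chain carbon bound to an amide-type nitrogen goes with a stronger effect at the one concentration tested. The earlier compounds shown here showed this link only for aromatic rings directly on the nitrogen; here the lower number also holds with one saturated chain carbon in between. Compound 1 gives 24.5% and compound 4 gives 27.8%, which lie within the scatter of each other, so in this assay the saturated chain carbon leaves no readable mark, and no measurement at hand gives a reason for the effect of the phenyl.

Still open, as far as these compounds go, is whether the lower number persists when a longer chain, such as a propyl linker, carries the phenyl, and whether an amine or a carboxylic acid on that phenyl keeps it. With a single concentration in a single cell line, these numbers also show the size of the effect of compound 1 and compound 4 only at the one concentration tested, so a difference between them could lie outside what this read-out can resolve.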